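Swapping the aryl group on a ghrelin receptor ligand

This account rests on a few compounds, and the source may have more. Where it says the series, first, only, none or still open, it means among the compounds named here.

Measured compounds:
compound 1 `CC(C)(N)C(=O)N[C@H](COCc1cccc(Cl)c1)c1nnnn1CCOC(=O)NCCCCO` gives 1.6 nM
compound 2 `CC(C)(N)C(=O)N[C@H](COCc1ccccc1C(F)(F)F)c1nnnn1CCOC(=O)NCCCCO` gives 0.72 nM

Both numbers come from a functional assay on cells for inhibition of growth hormone secretagogue receptor type 1 (Homo sapiens), read by FLIPR and calcium flux; on this read-out higher numbers stand for an effect only at larger amounts of compound and lower numbers for an effect already at smaller amounts. Compound 2 has the lowest of the two numbers; its nearest neighbour is compound 1, and the step of a 2.2-fold lower number from compound 1 to compound 2 (0.35 log units; beyond the scatter) is modest but beyond the scatter. Compound 3 `CC(C)(N)C(=O)N[C@H](COCc1ccc(OC(F)(F)F)cc1)c1nnnn1CCOC(=O)NCCCCO` has not yet been measured. It differs from compound 2 in one place: 4-(trifluoromethoxy)phenyl in place of 2-(trifluoromethyl)phenyl on a saturated chain carbon bound to an oxygen on a saturated carbon. Within the data shown here, the only measured step, a 2.2-fold lower number from compound 1 to compound 2 (0.35 log units; beyond the scatter), shows that exchanging one substituted phenyl for another at this place can move the number modestly. Among the measured compounds shown here, no measured pair, however, involves a trifluoromethoxy group, so the direction of the new exchange is not known from the data. For the measured compounds named here, with no direct precedent, the step of a 2.1-fold higher number from compound 2 to compound 3 (0.32 log units; beyond the scatter) is expected to be small, most likely within the scatter or a modest rise. Compound 3 is therefore estimated at 1.5 nM, with a range from 0.5 nM to 5 nM.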

Compound 3, half-maximal effective concentration: 33.2 nM
The estimate for compound 3 lay 22-fold (1.35 log units) below the measured number; measured number outside the range, above it.
By their numbers in this assay, from the lowest: compound 2; then compound 1; then compound 3.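

In this assay this position proves far less forgiving than the first exchange suggested: a 46-fold higher number from compound 2 to compound 3 (1.66 log units; beyond the scatter) is large, while a 2.2-fold lower number from compound 1 to compound 2 (0.35 log units; beyond the scatter) was only modest. The rise is not peculiar to compound 2, as a 21-fold higher number from compound 1 to compound 3 (1.32 log units; beyond the scatter) is large too, so 4-(trifluoromethoxy)phenyl stands apart from both 3-chlorophenyl and 2-(trifluoromethyl)phenyl on this read-out. Nothing available accounts for the size of this change.

As far as these compounds go, the exchange alters both the substituent and where it is printed on the phenyl, so it remains open whether 2-(trifluoromethoxy)phenyl or 4-(trifluoromethyl)phenyl would land nearer compound 2 or compound 3. Also open, from the compounds shown here alone, is how an unsubstituted phenyl, or a phenyl carrying an amine, would behave at this place.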